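The compounds below may be only part of what the source reports. "The series", "measured", "known", "first", "only" and "open" are said of these compounds alone.

Compounds 1 through 4 share one core and differ from one another only in two places. Compound 1 `COc1ccccc1NC(=O)NC1CC(C)(C)Oc2ccc(F)cc21` is the reference. In a functional assay (aorta) with Rattus norvegicus as the target (on this read-out lower numbers stand for an effect already at smaller amounts and higher numbers for an effect only at larger amounts of compound), compound 1 gives only a limit of the assay, > 10000 nM. Compound 2 `COc1ccccc1NC(=O)NC1CC(C)(C)Oc2ccc(Cl)cc21` differs from compound 1 by chloro in place of fluoro on an aromatic carbon. In this assay compound 2 likewise gives only a limit, > 10000 nM. The step that the two limits leave unreadable from compound 1 to compound 2 therefore cannot be sized; both values sit at the limit of > 10000 nM in this assay, at which 2 of the 3 values shown sit. Compound 3 `CC1(C)CC(NC(=O)Nc2cccc(Cl)c2)c2cc(F)ccc2O1` differs from compound 1 by 3-chlorophenyl in place of 2-methoxyphenyl on an amide-type nitrogen, which is how the two cores of compound 1 and compound 3 differ. In this assay compound 3 gives only a limit, > 300000 nM. The step that the two limits leave unreadable from compound 1 to compound 3 is likewise unreadable, since one value sits at the limit of > 10000 nM in this assay, at which 2 of the 3 values shown sit, and the other at the limit of > 300000 nM in this assay, at which 1 of the 3 values shown sits.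

Compound 4 `CC1(C)CC(NC(=O)Nc2cccc(Cl)c2)c2cc(Cl)ccc2O1` has not yet been measured in this assay. It differs from compound 3 by chloro in place of fluoro on an aromatic carbon, the same change, at the same place, as that from compound 1 to compound 2. That earlier change gave no readable step, with both ends at a limit. Compound 4 is therefore expected to return a limit again, resting on compound 3 giving only a limit, > 300000 nM, in this assay. The expected step is a number no higher from compound 3 to compound 4 (the limit leaves the size open). The estimate for compound 4 in this assay is 300000 nM, expected to lie between 30000 nM and 3000000 nM.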

Compound 4, half-maximal effective concentration: > 30000 nM
Compound 4: no number, only a limit; the forecaster's own chance of this, stated with the estimate: 85%; the middle value does not contradict the limit.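

In this assay compound 4 gives only a limit, > 30000 nM, and not a number. Compound 2 and compound 3 also give only limits, so neither step to compound 4 can be read, whether chloro in place of fluoro or 3-chlorophenyl in place of 2-methoxyphenyl. The compounds shown leave open whether either change shifts the concentration needed for an effect, and by how much.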